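One Bromo Step, Tried on a Second Core

This account rests on a few compounds, and the source may have more. Where it says the series, first, only, none or still open, it means among the compounds named here.

Compound 1 `COc1ccc(C2CC(c3ccccc3)=NN2C2=NC(=O)/C(=C3\C(=O)Nc4ccccc43)S2)cc1` and compound 2 `COc1ccc(C2CC(c3ccccc3)=NN2C2=NC(=O)/C(=C3\C(=O)Nc4ccc(Br)cc43)S2)cc1` share one core and differ in a single place: bromo in place of hydrogen on an aromatic carbon. In a functional assay on cells (Cancer cell lines, Homo sapiens) for cytotoxicity, read by sulforhodamine B assay, with a stated time of 48 h (on this read-out lower numbers stand for stronger inhibition of growth and higher numbers for weaker inhibition of growth), compound 1 gives 3350 nM, while compound 2 gives 660 nM. That single change produced a 5.1-fold lower number from compound 1 to compound 2 (0.71 log units; beyond the scatter).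

Compound 3 `COc1ccc(C2=NN(C3=NC(=O)/C(=C4\C(=O)Nc5ccccc54)S3)C(c3ccc(Cl)cc3)C2)cc1` is built on a different core; the difference between the two cores is not broken down here. In this assay compound 3 gives 100000 nM, the highest of the three numbers, with gaps to compound 1 and to compound 2 that both lie beyond the scatter.

Compound 4 `COc1ccc(C2=NN(C3=NC(=O)/C(=C4\C(=O)Nc5ccc(Br)cc54)S3)C(c3ccc(Cl)cc3)C2)cc1` has not yet been measured. It differs from compound 3 as bromo in place of hydrogen on an aromatic carbon, and the surroundings of the place are described in the same words as for the change from compound 1 to compound 2, so it is the same change carried onto the core of compound 3. The change has been seen only once among these compounds, so there is a single precedent to rest on. Because that precedent is a 5.1-fold lower number from compound 1 to compound 2 (0.71 log units; beyond the scatter), the expected step is a 5.0-fold lower number from compound 3 to compound 4 (0.70 log units; beyond the scatter), stated as an expectation with wide bounds, since compound 3 starts from 100000 nM and how the two cores respond to the same change is not known. Compound 4 is therefore expected to give about 20000 nM in this assay, estimated to fall between 5000 nM and 100000 nM.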

Compound 4, concentration for total growth inhibition: 1010 nM
The estimate for compound 4 lay 20-fold (1.30 log units) above the measured number; measured number outside the range, below it.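

In this assay, bromo in place of hydrogen on an aromatic carbon moved the number in the same direction on both cores, and on the core of compound 3 the change gave a 99-fold lower number from compound 3 to compound 4 (2.00 log units; beyond the scatter). The direction of the change therefore carried from one core to the other, but its size did not, and the two steps are clearly different: the same change on two cores in this assay, a 5.1-fold lower number (0.71 log units; beyond the scatter) from compound 1 to compound 2 and a 99-fold lower number (2.00 log units; beyond the scatter) from compound 3 to compound 4, 20-fold (1.29 log units) apart, beyond the scatter of two such steps

These two pairs show that, in this series, the size of the step on one core did not set its size on the other, but they do not explain the gap, identify which part of the cores is responsible for it, or give a rule that would extend to any further core.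

On these data alone, it remains open whether another group on the same aromatic carbon, such as fluoro, an amine or a carboxylic acid, would also move the number in the same direction on both cores, and whether its steps would differ as widely as those of bromo. As far as these compounds go, it is also open how the bromo step would behave on a core with a hydroxyl group in place of the methoxy group, or with a longer chain on its oxygen.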